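From Methoxy to Trifluoromethyl in a Cytotoxicity Series

The source may hold more compounds than are shown below. What is called first, only, known or untested is meant among the compounds shown, and "the series" means these compounds.

Measured in a functional assay on HCT-15 cells (Homo sapiens) for cytotoxicity, read by MTT assay, with a stated time of 2 days; on this read-out lower numbers stand for stronger inhibition and higher numbers for weaker inhibition:
Compound 1 `Cc1cccc(-c2nc3ccc(C)cc3c(=O)[nH]2)c1`: > 50000 nM (a limit)
Compound 2 `O=c1[nH]c(-c2cccc3ccccc23)nc2ccc(N3CCCCC3)cc12`: 2240 nM
Compound 3 `COc1cccc(-c2nc3cc(C)ccc3c(=O)[nH]2)c1`: 4850 nM

Of the two values that are true numbers, compound 3 carries the higher one at 4850 nM, while compound 2 at 2240 nM lies lower by more than the scatter. Compound 1 stands at > 50000 nM, which is a limit of the assay and not a number.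

Compound 4 `Cc1ccc2c(=O)[nH]c(-c3cccc(C(F)(F)F)c3)nc2c1` has not yet been measured. It differs from compound 3 by trifluoromethyl in place of methoxy on an aromatic carbon. For the measured compounds named here, no measured pair shows this change on its own, so the size of the step remains uncertain. The expected result is a modest step beyond the scatter toward a higher number, meaning weaker inhibition, and the estimate is a 2.5-fold higher number from compound 3 to compound 4 (0.39 log units; beyond the scatter). This expectation starts from compound 3 at 4850 nM. It leans upward with an eye on compound 1, which sits at the limit of > 50000 nM in this assay, at which 1 of the 3 values shown sits. In this assay, compound 4 is expected at 12000 nM, with an estimated range from 3000 nM to 45000 nM.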

Compound 4, half-maximal inhibitory concentration: > 50000 nM
Compound 4 ended at the assay's limit (the forecaster's own chance of this, stated with the estimate: 25%); at least 4.1-fold (0.61 log units) between middle value and limit.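

In this assay, for the compounds shown here, trifluoromethyl in place of methoxy on an aromatic carbon, meta to a large group, gives an at least 10-fold higher number from compound 3 to compound 4 (1.01 log units; beyond the scatter), and this is the first change that can be read on its own. Going by these compounds alone, the earlier compounds offered no pair differing in one place, so this step is the first sign that the group at this position can matter greatly for the read-out. Compound 4 gives > 50000 nM, which is a limit and not a number, so the step shows only the least size of the change: the limit of > 50000 nM in this assay, at which 2 of the 4 values shown sit.

As far as these compounds go, how far compound 4 lies past that limit stays open. So does whether another group at this position, such as a hydroxyl or an amine, would stay near compound 3 or fall away as trifluoromethyl does.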